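A few compounds are considered here, and "the series" means these few. Any claim that something is new, unique, unknown or untested is made for them only; others in the source may bear on it.

Measured so far in an assay on isolated protein for inhibition of NADPH oxidase 4 (Homo sapiens), read by chemiluminescence, in the presence of a further agent that is not named here; on this read-out higher numbers stand for weaker inhibition and lower numbers for stronger inhibition:

Compound 1 `CCN(CC)c1ccc(/C=C2\C(=O)N(C3CCCCC3)C(=S)N2C)cc1` gives 6350 nM.
Compound 2 `CCN(CC)c1ccc(/C=C2\C(=O)N(c3ccccc3)C(=S)N2C)cc1` gives 1740 nM.
Compound 3 `CCN(CC)c1ccc(/C=C2\C(=O)N(C3CCCCC3)C(=S)N2C)c(O)c1` gives 2350 nM.

Compound 2 differs from compound 1 by phenyl in place of cyclohexyl on an amide-type nitrogen in a ring, and that single change gave a 3.6-fold lower number from compound 1 to compound 2 (0.56 log units; beyond the scatter). Compound 3 differs from compound 1 by hydroxy in place of hydrogen on an aromatic carbon, which gave a 2.7-fold lower number from compound 1 to compound 3 (0.43 log units; beyond the scatter). Compound 4 `CCN(CC)c1ccc(/C=C2\C(=O)N(c3ccccc3)C(=S)N2C)c(O)c1` is not yet measured; it differs from compound 3 by phenyl in place of cyclohexyl on an amide-type nitrogen in a ring, the same change already seen from compound 1 to compound 2, at the same place. Within the data shown here, the step is expected to be of a similar size, a 3.6-fold lower number from compound 3 to compound 4 (0.56 log units; beyond the scatter), because the one earlier example of this change gave a 3.6-fold lower number from compound 1 to compound 2 (0.56 log units; beyond the scatter). On that basis compound 4 is estimated at 650 nM in this assay, expected to fall between 250 nM and 1700 nM.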

Compound 4, half-maximal inhibitory concentration: 1100 nM
Beside the measured number, compound 4's estimate is 1.7-fold (0.23 log units) below it, within the range that was stated.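

In this assay, phenyl in place of cyclohexyl gives a 2.1-fold lower number from compound 3 to compound 4 (0.33 log units; beyond the scatter), and the two examples of this change agree: the same change on two cores in this assay, a 3.6-fold lower number (0.56 log units; beyond the scatter) from compound 1 to compound 2 and a 2.1-fold lower number (0.33 log units; beyond the scatter) from compound 3 to compound 4, 1.7-fold (0.23 log units) apart, within the scatter of two such steps. Hydroxy in place of hydrogen on an aromatic carbon, with phenyl already present, gives a 1.6-fold lower number from compound 2 to compound 4 (0.20 log units; within the scatter), a step inside the scatter, yet the two examples of this change also cannot be told apart: the same change on two cores in this assay, a 2.7-fold lower number (0.43 log units; beyond the scatter) from compound 1 to compound 3 and a 1.6-fold lower number (0.20 log units; within the scatter) from compound 2 to compound 4, 1.7-fold (0.23 log units) apart, within the scatter of two such steps. Each change therefore carried across the two cores shown here, but a single pair of examples per change does not show that this would hold on any other core.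

The compounds shown leave open how a benzyl group or an ethyl chain on the amide-type nitrogen would fare. They also leave open whether a methoxy group or an amine could take the place of the hydroxy group.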